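Swapping amino for chloro: cytotoxicity of two cores

The source may report more compounds than this note shows. Statements on the series, on what has been measured and on what is new or still open speak of the compounds shown alone.

Compound 1 `Nc1ncnc2c1ncn2C[C@@H]1C[C@H](O)c2ccccc21` gives in an ADME assay on L1210/0 cells (Mus musculus) for cytotoxicity, with a stated time of 48 h (a lower number here means a stronger inhibitor, a higher number a weaker inhibitor), only a limit, > 200000 nM.
Compound 2 `O[C@H]1C[C@@H](Cn2cnc3c(Cl)ncnc32)c2ccccc21` gives in this assay likewise a limit, > 200000 nM.
Compound 3 `Nc1nc(N)c2ncn([C@H]3CCCC[C@H]3CO)c2n1` gives in this assay again a limit, > 200000 nM.

The change from compound 1 to compound 2 is chloro in place of amino on an aromatic carbon; its step is a step that the two limits leave unreadable from compound 1 to compound 2, because of the limit of > 200000 nM in this assay, at which 3 of the 3 values shown sit. The difference between the two cores of compound 1 and compound 3 is not broken down here. Compound 4 `Nc1nc(Cl)c2ncn([C@H]3CCCC[C@H]3CO)c2n1` carries the same kind of change on the core of compound 3, (chloro in place of amino on an aromatic carbon), where the place now also lies meta to an amino group (1 heavy atom). For compound 4 the expected step is a number no higher from compound 3 to compound 4 (the limit leaves the size open), resting on the unreadable a step that the two limits leave unreadable from compound 1 to compound 2 and on (the limit of > 200000 nM in this assay, at which 3 of the 3 values shown sit). Compound 4 is therefore estimated at 200000 nM in this assay, most likely again reported only as a limit.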

Compound 4, half-maximal inhibitory concentration: > 200000 nM
Compound 4 ended at the assay's limit (the forecaster's own chance of this, stated with the estimate: 85%); the middle value sits exactly at the limit.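

No step can be read from compound 3 to compound 4, because both values are limits: the limit of > 200000 nM in this assay, at which 4 of the 4 values shown sit. The compounds shown leave open whether chloro in place of amino shifts the result in this assay on either core.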